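A few compounds are considered here, and "the series" means these few. Any claim that something is new, unique, unknown or untested is made for them only; others in the source may bear on it.

In an in vitro functional assay on cells for antagonist activity at transient receptor potential cation channel subfamily V member 1 (Homo sapiens), read by FLIPR and calcium flux (a higher number here means a weaker inhibitor, a lower number a stronger inhibitor), compound 1 `Cc1ccccc1-c1cnc(Nc2cccc3c2CC(O)CC3)o1` gives 416 nM. Among the compounds with values here, of the two compounds measured so far, compound 1 stands with the higher number: compound 2 `OC1CCc2cccc(Nc3ncc(-c4ccc(N5CCCC5)cc4)o3)c2C1` gives 101 nM in this assay, and the gap between these two values lies beyond the usual scatter. Compound 3 `OC1CCc2cccc(Nc3ncc(Cc4ccccc4)o3)c2C1` is not yet measured. It differs from compound 1 in a single place: benzyl in place of 2-methylphenyl on an aromatic carbon. Within the data shown here, no measured pair in this set shows the effect of such a change, so any expectation for it rests on judgement alone. The step of a 3.1-fold higher number from compound 1 to compound 3 (0.49 log units; beyond the scatter) is expected to go toward a weaker inhibitor, of a size that lies beyond the scatter but is far from certain in either direction. In this assay compound 3 is expected to give 1300 nM, with a plausible range from 400 nM to 4500 nM.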

Compound 3, half-maximal inhibitory concentration: 1820 nM
Compound 3: middle estimate off by 1.4-fold (0.15 log units), on the low side; the measured number falls inside the stated range.
By their numbers in this assay, from the lowest: compound 2; then compound 1; then compound 3.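

In this assay, within the data shown here, the change to benzyl in place of 2-methylphenyl, on the aromatic carbon next to the ring oxygen, gives a measured step at this position for the first time: a 4.4-fold higher number from compound 1 to compound 3 (0.64 log units; beyond the scatter). Compounds 1 and 3 hold the same atoms joined differently, so this position is sensitive to how the carbon ring is attached and not only to which atoms are present. The available data offer no explanation for this step.

The compounds shown leave open how an unsubstituted phenyl at this place would compare with 2-methylphenyl, and so whether the methyl group or the direct ring attachment accounts for the difference. They also leave open whether a longer chain such as 2-phenylethyl would move the number further in the same direction.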